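This account rests on a few compounds, and the source may have more. Where it says the series, first, only, none or still open, it means among the compounds named here.

Compound 2 `CCOc1nc(N)nc2c1ncn2/C=C1/CC1(CO)CO` and compound 1 `Nc1nc(OCC(F)(F)F)c2ncn(/C=C3/CC3(CO)CO)c2n1` share one core and differ only by a methyl in place of a trifluoromethyl on a saturated chain carbon bound to an oxygen on an aromatic ring. In an ADME assay on HFF cells (Homo sapiens) for cytotoxicity, with a stated time of 8 days (on this read-out higher numbers stand for lower toxicity in this test and lower numbers for higher toxicity in this test), compound 1 gives > 300000 nM, which is a limit of the test and not a number. In this assay compound 2 gives > 300000 nM, again a limit. The step that the two limits leave unreadable from compound 1 to compound 2 therefore cannot be read, because of the limit of > 300000 nM in this assay, at which 2 of the 2 values shown sit. Compound 3 `CCCCNc1nc(N)nc2c1ncn2/C=C1/CC1(CO)CO` has not yet been measured; it differs from compound 2 by butylamino in place of ethoxy on an aromatic carbon. Within the data shown here, no measured step covers a change of this kind, and the single measured pair offers only limits, so no direction beyond the scatter can be expected. Compound 3 is expected to give about 300000 nM in this assay, between 100000 nM and 1000000 nM. The step of a number no higher from compound 2 to compound 3 (the limit leaves the size open) that this estimate means is expected to stay within the scatter.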

Compound 3, half-maximal cytotoxic concentration: > 300000 nM
Compound 3 was reported as a limit; the forecaster's own chance of this, stated with the estimate: 80%; the middle value sits exactly at the limit.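

Among these compounds, compound 3 gives a limit and not a number in this assay, as do compound 1 and compound 2, so no step among the three can be read: the limit of > 300000 nM in this assay, at which 3 of the 3 values shown sit. The compounds shown leave open at what concentration, if any, each of the three would harm these cells, and whether butylamino, ethoxy and 2,2,2-trifluoroethoxy differ in this respect.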